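Extending an ethoxy to a geranyl ether: an untested change

The compounds below may be only part of what the source reports. "The series", "measured", "known", "first", "only" and "open" are said of these compounds alone.

Measured compounds:
Compound 1, `O=C(/C=C/c1ccc(OCC(F)(F)F)cc1)NNC(=O)c1ccncc1`: in an ADME assay on THP-1 cells (Homo sapiens) for cytotoxicity, read by MTT assay, with a stated time of 72 h (a lower number here means a stronger inhibitor, a higher number a weaker inhibitor), compound 1 gives "not determined" (no result reported)
Compound 2, `CCOc1ccc(/C=C/C(=O)N/N=c2/[nH]ncc3ccccc23)cc1`: in this assay compound 2 gives "not determined" (no result reported)
Compound 3, `COc1ccc(/C=C/C(=O)NNC(=O)c2ccncc2)cc1`: in this assay compound 3 gives 168000 nM

Compound 2, `CCOc1ccc(/C=C/C(=O)N/N=c2/[nH]ncc3ccccc23)cc1`, has no number in this assay, where compound 2 is recorded as "not determined" (no result reported); it is one of two compounds in this set without a reported result, and the only figure in hand is that of compound 3, which shows weak cytotoxicity. Compound 4, `CC(C)=CCC/C(C)=C/COc1ccc(/C=C/C(=O)N/N=c2/[nH]ncc3ccccc23)cc1`, is the untested partner of compound 2. The change between them is 2,6-dimethylhepta-1,5-dien-1-yl in place of methyl on a saturated chain carbon bound to an oxygen on an aromatic ring. Going by the values given here, no pair of measured compounds shares this change, so its size is not known from the data. Among the compounds with values here, the single measured value belongs to compound 3, whose core differs from that of compound 2, and it offers only a rough anchor for where this series sits. Given that, the expectation for compound 4 in this assay is a number in the weak range, with a wide margin either way. Compound 4 is expected to give 100000 nM, in the range 30000 nM to 300000 nM.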

Compound 4, half-maximal inhibitory concentration: 56000 nM
Estimate against measurement, compound 4: 1.8-fold (0.25 log units) above; measured number inside the range.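

Going by these compounds alone, compound 4 gives 56000 nM in this assay, but compound 2 has no number there, so no step between the two can be read. Nothing available offers an explanation of this result. From the compounds shown here alone, what replacing ethoxy with (3,7-dimethylocta-2,6-dien-1-yl)oxy does to the value remains open.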